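This account rests on a few compounds, and the source may have more. Where it says the series, first, only, none or still open, it means among the compounds named here.

Measured so far:
- compound 1 `COc1ccc(C(=O)Nc2ccc(C(=O)/C=C/c3nc(C)c(C)nc3C)cc2)cc1` gives 1190 nM
- compound 2 `Cc1nc(C)c(/C=C/C(=O)c2ccc(NC(=O)c3ccccc3F)cc2)nc1C` gives 2040 nM

Among the measured compounds shown here, in a functional assay on HepG2 cells (Homo sapiens) for antiproliferative activity, read by CCK-8 assay, with a stated time of 72 h (on this read-out higher numbers stand for weaker inhibition and lower numbers for stronger inhibition), compound 2 gives the highest of the two numbers so far; its nearest neighbour is compound 1, and the single measured step, a 1.7-fold higher number from compound 1 to compound 2 (0.23 log units; within the scatter), lies within the scatter, so the two numbers cannot be ordered against each other.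

Compound 3 `COc1cccc(OC)c1C(=O)Nc1ccc(C(=O)/C=C/c2nc(C)c(C)nc2C)cc1` is the next compound to be measured. It differs from compound 2 in one place: 2,6-dimethoxyphenyl in place of 2-fluorophenyl on a carbonyl carbon. For the measured compounds named here, the only step that bears on this is the one that touches the same carbonyl carbon, a 1.7-fold higher number from compound 1 to compound 2 (0.23 log units; within the scatter), and it changed the number by less than the scatter. A methoxy-bearing phenyl ring is therefore already represented by compound 1 at 1190 nM, and the exchange of the phenyl ring on this carbonyl has so far not moved this assay beyond its noise.

For compound 3 the expectation is accordingly a number close to that of compound 2, with a 1.3-fold lower number from compound 2 to compound 3 (0.11 log units; within the scatter) as the expected step, not beyond the scatter in either direction. The estimate for compound 3 is 1600 nM, with a range from 500 nM to 5000 nM.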

Compound 3, half-maximal inhibitory concentration: 3380 nM
Beside the measured number, compound 3's estimate is 2.1-fold (0.32 log units) below it; measured number inside the range.
By their numbers in this assay, from the lowest: compounds 1, 2 and 3 (each within the scatter of the next, the first and the last beyond it).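

In this assay the exchange of the aryl group on the carbonyl carbon, whose other neighbour is the amide-type nitrogen, now gives its first step beyond the scatter: with 2,6-dimethoxyphenyl in place of 4-methoxyphenyl there is a 2.8-fold higher number from compound 1 to compound 3 (0.45 log units; beyond the scatter) and that step is modest. With 2,6-dimethoxyphenyl in place of 2-fluorophenyl there is a 1.7-fold higher number from compound 2 to compound 3 (0.22 log units; within the scatter) and that step stays within the scatter, so the only separation in this set lies between the two methoxy-bearing members, which shows that the presence of methoxy on the phenyl ring does not by itself fix the number at this position. Nothing at hand gives a measured reason for this difference.

Going by these compounds, the shared core is the same in all three compounds, so the response to changes anywhere else in the structure remains unknown, and the small aryl set gives no trend across substituents on this carbonyl carbon. On these data alone, whether a phenyl ring carrying an amine or a carboxylic acid, or a longer chain in place of the phenyl ring, would move the number beyond the scatter remains open.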